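Swapping an Aryl Amine for Piperazine on a Shared Core

A few compounds are considered here, and "the series" means these few. Any claim that something is new, unique, unknown or untested is made for them only; others in the source may bear on it.

Of the compounds shown here, two sharing one core have been measured in a functional assay on MCF7 cells (Homo sapiens) for cytotoxicity, read by MTT assay, with a stated time of 72 h; a higher number here means a weaker inhibitor, a lower number a stronger inhibitor. Compound 1 `COc1ccc(Nc2cc(C)nc(SCc3nc4ccccc4[nH]3)n2)cc1` gives 61100 nM in this assay. Compound 2 `Cc1ccc(Nc2cc(C)nc(SCc3nc4ccccc4[nH]3)n2)cc1` gives 56500 nM in this assay. Going by the values given here, the one step between them, a 1.1-fold lower number from compound 1 to compound 2 (0.03 log units; within the scatter), changes nothing that the scatter could not explain, so compound 2 stands lowest of the two numbers only nominally, with compound 1 within the scatter of it.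

Compound 3 `Cc1cc(N2CCNCC2)nc(SCc2nc3ccccc3[nH]2)n1` is the next compound, and it differs from compound 2 as follows: piperazin-1-yl in place of (4-methylphenyl)amino on an aromatic carbon. Among the compounds with values here, no measured step bears on this kind of change; the only known step concerns a small swap on the outer aromatic ring, not the replacement of that whole ring and its amine by a saturated diamine. The expectation for this assay therefore rests on the two high numbers seen so far, with a wide range to reflect the missing precedent. Compound 3 is estimated at 50000 nM, within 15000 nM to 150000 nM, which corresponds to an expected step of a 1.1-fold lower number from compound 2 to compound 3 (0.05 log units; within the scatter).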

Compound 3, half-maximal inhibitory concentration: > 100000 nM
Compound 3 gave a limit, no number (the forecaster's own chance of this, stated with the estimate: 20%); at least 2.0-fold (0.30 log units) between middle value and limit.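

In this assay compound 3 gives > 100000 nM as its result, which is a limit of the assay and not a number: the limit of > 100000 nM in this assay, at which 1 of the 3 values shown sits. Putting piperazin-1-yl in place of the aromatic amine on this aromatic carbon gives an at least 1.7-fold higher number from compound 2 to compound 3 (0.24 log units; that floor lies within the scatter) for the (4-methylphenyl)amino starting point and an at least 1.6-fold higher number from compound 1 to compound 3 (0.21 log units; that floor lies within the scatter) for the (4-methoxyphenyl)amino one, and each of these is only a floor that lies within the scatter, so neither shows a real loss on its own. Going by these compounds alone, still, the earlier pair changed only one small group on the outer ring, whereas this change replaces the whole arylamino group with a saturated ring, and even so it brings no measurable gain in this assay, since the result does not come down to a number.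

On these data alone, how far compound 3 lies past the limit stays open, so the true size of this change cannot be read from these compounds. Also open, as far as these compounds go, is whether a morpholine ring, a simple alkyl amine or a benzylamino group at this same place would give a lower number than the aromatic amines do in this assay.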